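Propoxy in Place of Propylamino: An Expected Cytotoxicity Value

This account rests on a few compounds, and the source may have more. Where it says the series, first, only, none or still open, it means among the compounds named here.

Of the compounds shown here, three sharing one core have been tested in an ADME assay on HFF cells (Homo sapiens) for cytotoxicity, with a stated time of 8 days; a lower number here means that less compound is tolerated, a higher number that more compound is tolerated. Compound 1 `Nc1nc(OCc2ccccc2)c2ncn(/C=C3/CC3(CO)CO)c2n1` carries a benzyloxy group; in this assay compound 1 gives > 300000 nM, which is a limit of the assay rather than a number. Compound 2 `Nc1nc(NCc2ccccc2)c2ncn(/C=C3/CC3(CO)CO)c2n1` carries benzylamino in place of benzyloxy; in this assay compound 2 gives > 300000 nM, again a limit. Compound 3 `CCCNc1nc(N)nc2c1ncn2/C=C1/CC1(CO)CO` carries propylamino in place of benzyloxy; in this assay compound 3 gives > 300000 nM, also a limit. Compound 3 therefore stands where the other two stand, at the limit of > 300000 nM in this assay, at which 3 of the 3 values shown sit, and none of the three is distinguished from the others. The steps between them cannot be sized: a step that the two limits leave unreadable from compound 1 to compound 2, a step that the two limits leave unreadable from compound 1 to compound 3 and a step that the two limits leave unreadable from compound 2 to compound 3 all fall between two limits.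

Compound 4 `CCCOc1nc(N)nc2c1ncn2/C=C1/CC1(CO)CO` has not yet been measured. It differs from compound 3 by propoxy in place of propylamino on an aromatic carbon. Going by the values given here, no measured step bears directly on an exchange of propylamino for propoxy; the nearest comparison, oxygen against nitrogen in the larger benzyl pair, is a step that the two limits leave unreadable from compound 1 to compound 2 and lies between two limits. With every value of the set at the limit, no step beyond the scatter is expected in this assay in either direction. Compound 4 is accordingly expected to give 300000 nM in this assay, with a range from 100000 nM to 1000000 nM. The step this estimate implies, a number no higher from compound 3 to compound 4 (the limit leaves the size open), is expected to stay within the scatter.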

Compound 4, half-maximal cytotoxic concentration: > 300000 nM
Compound 4 gave a limit, no number; the forecaster's own chance of this, stated with the estimate: 85%; the middle value sits exactly at the limit.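

In this assay compound 4 gives > 300000 nM, a limit of the assay and not a number. Its steps to compound 1, compound 2 and compound 3 cannot be read, and all four compounds stand at the same limit: the limit of > 300000 nM in this assay, at which 4 of the 4 values shown sit. The compounds shown leave open how far the four differ, and at what concentration any of them becomes cytotoxic.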